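Compound 3: selenium in place of sulfur

The source may report more compounds than this note shows. Statements on the series, on what has been measured and on what is new or still open speak of the compounds shown alone.

For the measured compounds named here, compound 2 `CS/C(=N\C(=O)c1cc(-c2ccccc2)nc2ccccc12)NC(=O)c1cc(-c2ccccc2)nc2ccccc12` gives 43100 nM in a functional assay on MCF7 cells (Homo sapiens) for cytotoxicity, read by MTT assay, with a stated time of 72 h (a lower number here means a stronger inhibitor of growth, a higher number a weaker inhibitor of growth), the highest of the two numbers so far. Its nearest neighbour is compound 1 `O=C(/N=C(/NC(=O)c1cc(-c2ccccc2)nc2ccccc12)[Se]Cc1ccccc1)c1cc(-c2ccccc2)nc2ccccc12`, which in this assay gives 8460 nM; the step of a 5.1-fold higher number from compound 1 to compound 2 (0.71 log units; beyond the scatter) lies beyond the scatter. Compound 3 `C[Se]/C(=N\C(=O)c1cc(-c2ccccc2)nc2ccccc12)NC(=O)c1cc(-c2ccccc2)nc2ccccc12` differs from compound 2 by a group of 2 heavy atoms (1 carbon, 1 selenium; no ring) in place of a group of 2 heavy atoms (1 carbon, 1 sulfur; no ring), on a carbon with a double bond to nitrogen. Going by the values given here, only one measured step bears on this change, and only in part: from compound 1 to compound 2 the selenium left together with the whole group of 8 heavy atoms carrying the aromatic ring, so that step mixes two changes and the data do not allow the selenium share to be split off. A lower number for compound 3 is expected, but a smaller move than the measured step, since compound 3 keeps the single-carbon group of compound 2 and takes up only the selenium of compound 1. The estimated step is a 2.2-fold lower number from compound 2 to compound 3 (0.33 log units; beyond the scatter). Compound 3 is expected at 20000 nM, within 7000 nM to 55000 nM.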

Compound 3, concentration for 50% growth inhibition: 490 nM
Compound 3: the middle estimate sits 41-fold (1.61 log units) above what was measured; the measured number lies below the stated range.
By their numbers in this assay, from the lowest: compound 3; then compound 1; then compound 2.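

In this assay the exchange of methylsulfanyl for the group of one carbon and one selenium, on a carbon with a double bond to nitrogen, gives an 88-fold lower number from compound 2 to compound 3 (1.94 log units; beyond the scatter). This isolates a large selenium-for-sulfur step. The mixed step from compound 1 to compound 2 could not separate it. With selenium held in place, hydrogen in place of phenyl on the saturated chain carbon bound to selenium gives a 17-fold lower number from compound 1 to compound 3 (1.24 log units; beyond the scatter) and shows that the aromatic ring of compound 1 is not required for growth inhibition in this pair. No measurement available here bears on the cause of either step.

From the compounds shown here alone, whether the selenium-for-sulfur step keeps its size with a benzylsulfanyl group or a longer chain on the heteroatom remains open. Also open, going by these compounds, is how an amine at this carbon would compare.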